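Allyloxy Swapped for (Methylsulfonyl)methyl on a Shared Core

The source may hold more compounds than are shown below. What is called first, only, known or untested is meant among the compounds shown, and "the series" means these compounds.

Compound 1 `C=CCOc1cc(/C=C/C(=O)c2ccc(OC)c3c2OC(C)(C)C=C3)ccc1OC` is the starting point. In a functional assay on A-375 cells (Homo sapiens) for cytotoxicity, read by MTT assay (a lower number here means a stronger inhibitor, a higher number a weaker inhibitor), compound 1 gives > 10000 nM, which is a limit of the assay rather than a measured number, so compound 1 can only be placed at the weak end of the measured set (the limit of > 10000 nM in this assay, at which 1 of the 3 values shown sits). Two measured relatives alter the same oxygen. Compound 2 `CCCCC(=O)Oc1cc(/C=C/C(=O)c2ccc(OC)c3c2OC(C)(C)C=C3)ccc1OC` gives 220 nM in this assay, and the step is an at least 45-fold lower number from compound 1 to compound 2 (1.65 log units; beyond the scatter). Compound 3 `COc1cccc(C(=O)Oc2cc(/C=C/C(=O)c3ccc(OC)c4c3OC(C)(C)C=C4)ccc2OC)c1` gives 800 nM in this assay, with the step of an at least 12-fold lower number from compound 1 to compound 3 (1.09 log units; beyond the scatter). Between those two, a 3.6-fold higher number from compound 2 to compound 3 (0.56 log units; beyond the scatter).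

Compound 4 `COc1ccc(/C=C/C(=O)c2ccc(OC)c3c2OC(C)(C)C=C3)cc1CS(C)(=O)=O` goes a different way: (methylsulfonyl)methyl in place of allyloxy on an aromatic carbon. Both measured steps kept the oxygen and hung a carbonyl on it, and both gave large gains. Going by the values given here, compound 4 removes the oxygen and its allyl together and puts in a (methylsulfonyl)methyl, a change no measured pair covers, so the two large steps from compound 1 can only suggest that its limit leaves much room for improvement, not how much of that room this particular change claims. A gain is therefore expected, but a smaller and less certain one. Compound 4 is estimated at 3000 nM, with a range from 500 nM to 15000 nM. The expected step is an at least 3.3-fold lower number from compound 1 to compound 4 (0.52 log units; beyond the scatter).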

Compound 4, half-maximal inhibitory concentration: > 10000 nM
Compound 4: only a limit was reported (the forecaster's own chance of this, stated with the estimate: 30%); middle value at least 3.3-fold (0.52 log units) away from the limit.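

Compound 4 gives no measured number in this assay, only a limit, and this places it with compound 1 at the weak end of the set: the limit of > 10000 nM in this assay, at which 2 of the 4 values shown sit. The comparison with the two compounds that carry a carbonyl on the oxygen can still be read, and it shows a large loss: an at least 12-fold higher number from compound 3 to compound 4 (1.09 log units; beyond the scatter), and an at least 45-fold higher number from compound 2 to compound 4 (1.65 log units; beyond the scatter). So the first change tried away from the oxygen gives no sign of the gain seen with those carbonyl groups, and within these four compounds a measured number appears only in compound 2 and compound 3, while allyloxy in compound 1 and (methylsulfonyl)methyl in compound 4 both stay at the limit.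

From the compounds shown here alone, with a limit on both sides, the step between compound 1 and compound 4 cannot be read, so it remains unknown which of the two groups is the weaker. Also open, going by these compounds, is whether the gain depends on the oxygen, the carbonyl or both, which an amide joined through nitrogen, a ketone joined through carbon or a shorter acetyl ester at this position could help to separate.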